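A Phenol Sulfonyl Ester and Its Expected Effect on Cytotoxicity

A few compounds are considered here, and "the series" means these few. Any claim that something is new, unique, unknown or untested is made for them only; others in the source may bear on it.

Compound 1 `Cc1ccc(S(=O)(=O)Oc2ccc3c(c2C)[C@H](Cn2cc(-c4ccccn4)nn2)[C@@]24CC(=O)[C@@](C)(CC[C@@H]32)C4)cc1`: > 20000 nM
Compound 2 `Cc1c(O)ccc2c1[C@H](Cn1cc(-c3ccccn3)nn1)[C@@]13CC(=O)[C@@](C)(CC[C@@H]21)C3`: > 20000 nM
Compound 3 `C=C1C(=O)[C@]23C[C@@]1(O)CC[C@H]2c1ccc(O)c(C)c1[C@@H]3Cn1cc(-c2ccc(F)cc2)nn1`: 660 nM

Of the compounds shown here, three have been measured in a functional assay on HL-60 cells (Homo sapiens) for cytotoxicity, read by MTT assay, with a stated time of 4 days; a lower number here means a stronger inhibitor, a higher number a weaker inhibitor. For compound 2 the result is a limit of the assay, > 20000 nM. For compound 1 the result is likewise a limit, > 20000 nM. For the measured compounds named here, compound 3 is the only one with a number: in this assay compound 3 gives 660 nM. The difference between the cores of compound 2 and compound 3 is not broken down here.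

From compound 2 to compound 1 the change is (4-methylphenyl)sulfonyl in place of hydrogen on an oxygen on an aromatic ring, and the step it made is a step that the two limits leave unreadable from compound 2 to compound 1, because the limit of > 20000 nM in this assay, at which 2 of the 3 values shown sit, holds both ends. The same change is now applied to compound 3 to give compound 4 `C=C1C(=O)[C@]23C[C@@]1(O)CC[C@H]2c1ccc(OS(=O)(=O)c2ccc(C)cc2)c(C)c1[C@@H]3Cn1cc(-c2ccc(F)cc2)nn1`: (4-methylphenyl)sulfonyl in place of hydrogen on an oxygen on an aromatic ring. Since the earlier step gives no readable size, the expectation for compound 4 rests on compound 3 alone, with 660 nM as its anchor, and a step of a 2.3-fold higher number from compound 3 to compound 4 (0.36 log units; beyond the scatter) is expected. Compound 4 is thus estimated at 1500 nM, within 400 nM to 8000 nM.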

Compound 4, half-maximal inhibitory concentration: 1290 nM
For compound 4 the middle estimate is 1.2-fold (0.07 log units) above the measured one, and the stated range covers the measured number.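

In this assay, placing (4-methylphenyl)sulfonyl on the oxygen of the aromatic ring of compound 3 gives a 2.0-fold higher number from compound 3 to compound 4 (0.29 log units; within the scatter), so on this core the hydroxy can carry the added group without a step beyond the scatter. On the core of compound 2 the same change cannot be read, because compound 2 and compound 1 both sit at a limit of the assay: the limit of > 20000 nM in this assay, at which 2 of the 4 values shown sit. The series therefore offers one readable size for this change, on one core, and this shows nothing about whether that size carries over to another core.

The cores of compound 2 and compound 3 also differ in more than one place, so what separates their results stays unresolved. Going by these compounds, it also remains open whether a smaller group on the same oxygen, such as methylsulfonyl or acetyl, or an amine in place of the hydroxy, would stay within the scatter of compound 3.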